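A few compounds are considered here, and "the series" means these few. Any claim that something is new, unique, unknown or untested is made for them only; others in the source may bear on it.

Of the compounds shown here, three sharing one core have been tested in a functional assay on OVCAR-8 cells (Homo sapiens) for cytotoxicity, read by sulforhodamine B assay, with a stated time of 48 h; on this read-out higher numbers stand for weaker inhibition of growth and lower numbers for stronger inhibition of growth. Compound 3 `ClCc1ccc(Cn2cnc3c(Cl)nc(Cl)nc32)cc1` gives 20000 nM, compound 1 `Nc1nc(Cl)c2ncn(Cc3ccc(CCl)cc3)c2n1` gives 5130 nM, and compound 2 `ClCc1cccc(Cn2cnc3c(Cl)nc(Cl)nc32)c1` gives 1820 nM, the lowest of the three numbers. The step of a 3.9-fold lower number from compound 3 to compound 1 (0.59 log units; beyond the scatter) follows from the change (amino in place of chloro on an aromatic carbon). Compound 2 and compound 3 have the same atoms joined differently; the difference between the two cores is not broken down here. Compound 4 `Nc1nc(Cl)c2ncn(Cc3cccc(CCl)c3)c2n1` has not yet been measured; it differs from compound 2 by amino in place of chloro on an aromatic carbon, the same change at the same place. Because compound 1 reached 5130 nM after that change, compound 4 is expected in this assay to show a 3.6-fold lower number from compound 2 to compound 4 (0.56 log units; beyond the scatter), a step close in size to a 3.9-fold lower number from compound 3 to compound 1 (0.59 log units; beyond the scatter). Compound 4 is therefore estimated at 500 nM, most likely between 200 nM and 1500 nM.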

Compound 4, concentration for 50% growth inhibition: 2290 nM
Compound 4: the middle estimate sits 4.6-fold (0.66 log units) below what was measured, and the stated range ends below it.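

In this assay amino in place of chloro on an aromatic carbon gave a 1.3-fold higher number from compound 2 to compound 4 (0.10 log units; within the scatter) and so did not repeat the step seen on the other core. The same change therefore differs in size between the two cores: the same change on two cores in this assay, a 3.9-fold lower number (0.59 log units; beyond the scatter) from compound 3 to compound 1 and a 1.3-fold higher number (0.10 log units; within the scatter) from compound 2 to compound 4, 4.9-fold (0.69 log units) apart, beyond the scatter of two such steps. With one pair per core, this shows that the step cannot be carried over as a fixed amount between these two cores, but it does not show why, or how the change would behave on any further core.

The compounds shown leave open whether a methylamino or methoxy group at that place would follow either step. They also leave open what a hydroxymethyl group in place of chloromethyl would do on either core.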